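From 3-chloro-4-fluorophenyl to 2,4-dichlorophenyl

A few compounds are considered here, and "the series" means these few. Any claim that something is new, unique, unknown or untested is made for them only; others in the source may bear on it.

In a functional assay on T-24 cells (Homo sapiens) for antiproliferative activity, read by MTT assay, with a stated time of 48 h (on this read-out higher numbers stand for weaker inhibition and lower numbers for stronger inhibition), compound 1 (`Cc1cccc(NC(=O)Nc2cccc(CNc3nccnc3Cl)c2)c1`) gives 9570 nM and compound 2 (`O=C(Nc1cccc(CNc2nccnc2Cl)c1)Nc1ccc(F)c(Cl)c1`) gives 4990 nM so compound 2 stands level with compound 1 within the scatter. Compound 3 (`O=C(Nc1cccc(CNc2nccnc2Cl)c1)Nc1ccc(Cl)cc1Cl`) carries 2,4-dichlorophenyl in place of 3-chloro-4-fluorophenyl on an amide-type nitrogen, and 2,4-dichlorophenyl in place of 3-chloro-4-fluorophenyl on an amide-type nitrogen counts that exchange. Within the data shown here, the only measured step at this place is a 1.9-fold lower number from compound 1 to compound 2 (0.28 log units; within the scatter) and it stays within the scatter. On that single step, no change beyond the scatter is expected in this assay for this exchange. Compound 3 is estimated at 5000 nM with an expected range of 2000 nM to 12000 nM in this read-out.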

Compound 3, half-maximal inhibitory concentration: 5740 nM
Compound 3: middle estimate off by 1.1-fold (0.06 log units), on the low side, within the range that was stated.
By their numbers in this assay, from the lowest: compounds 2, 3 and 1 (each within the scatter of the next).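

Across three aryl groups on the amide-type nitrogen, the values in this assay do not separate: a 1.2-fold higher number from compound 2 to compound 3 (0.06 log units; within the scatter) and a 1.7-fold lower number from compound 1 to compound 3 (0.22 log units; within the scatter) both stay within the scatter. 2,4-Dichlorophenyl therefore reads level with both 3-chloro-4-fluorophenyl and 3-methylphenyl, so the exchange gives no measurable handle at this position. No supporting data bear on this flat reading. Still open, from the compounds shown here alone, is whether a clear step appears with a different group here, such as a 4-methoxyphenyl, a 4-carboxyphenyl or a simple alkyl chain.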